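A few compounds are considered here, and "the series" means these few. Any claim that something is new, unique, unknown or untested is made for them only; others in the source may bear on it.

Compound 1 `C=C1C(=O)O[C@H]2[C@H]1CC/C(COC(=O)Cn1cc(F)c(=O)[nH]c1=O)=C\CC[C@@]1(C)O[C@@H]21`: > 20000 nM
Compound 2 `C=C1C(=O)O[C@H]2[C@H]1CC/C(COC(=O)Cn1cc(F)c(=O)n(Cc3ccc(Cl)cc3)c1=O)=C\CC[C@@]1(C)O[C@@H]21`: 2420 nM

Both compounds were tested in a functional assay on Bel7402/5-FU cells (Homo sapiens) for antiproliferative activity, read by MTT assay, with a stated time of 72 h; on this read-out higher numbers stand for weaker inhibition and lower numbers for stronger inhibition. Compound 1 reached only the limit of that test, (the limit of > 20000 nM in this assay, at which 1 of the 2 values shown sits), so for compound 1 there is no number, only a boundary. Compound 2 gave 2420 nM in this assay. Going by the values given here, the single measured step, an at least 8.2-fold lower number from compound 1 to compound 2 (0.91 log units; beyond the scatter), is therefore known only as a minimum.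

Compound 3 `C=C1C(=O)O[C@H]2[C@H]1CC/C(COC(=O)Cn1cc(F)c(=O)n(CCC)c1=O)=C\CC[C@@]1(C)O[C@@H]21` has not yet been measured in this assay. It differs from compound 1 in one place: propyl in place of hydrogen on an aromatic nitrogen. Among the compounds with values here, the only step that bears on this change put 4-chlorobenzyl on the same aromatic nitrogen and gave an at least 8.2-fold lower number from compound 1 to compound 2 (0.91 log units; beyond the scatter). Propyl carries no ring, unlike 4-chlorobenzyl, so a step in the same direction, though of uncertain size, is expected here. The expected step is an at least 2.5-fold lower number from compound 1 to compound 3 (0.39 log units; beyond the scatter). Compound 3 is therefore estimated to give 8000 nM in this assay, within 2500 nM to 30000 nM, with a real chance that it again comes back only as a limit.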

Compound 3, half-maximal inhibitory concentration: 9110 nM
Beside the measured number, compound 3's estimate is 1.1-fold (0.06 log units) below it; the measured number falls inside the stated range.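

Putting propyl on the aromatic nitrogen also lowers the number, with an at least 2.1-fold lower number from compound 1 to compound 3 (0.34 log units; beyond the scatter), so in this assay a substituent with no ring is enough for a step beyond the scatter. The size of this step is known only as a minimum, since the value of compound 1 is a limit and not a number: the limit of > 20000 nM in this assay, at which 1 of the 3 values shown sits. The ring-bearing group still gives the lower number, as ethyl in place of 4-chlorophenyl on the saturated chain carbon bound to the aromatic nitrogen gives a 3.8-fold higher number from compound 2 to compound 3 (0.58 log units; beyond the scatter), a step that can be read in full.

What the two substituents leave open is which part of 4-chlorobenzyl accounts for that gap, and a plain benzyl group would separate the ring from the chlorine. From the compounds shown here alone, how the number follows the chain itself also remains open, and a longer chain such as hexyl, or a propyl chain ending in an amine, would show whether the trend continues and whether a chain of this length tolerates a charged end.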